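This account rests on a few compounds, and the source may have more. Where it says the series, first, only, none or still open, it means among the compounds named here.

Compound 1 `CC(=O)O[C@@H]1CC(C)=C(CCC2=CC(=O)OC2)[C@@]2(C)CCCC(C)(C)[C@H]12` gives < 5 ug/mL in a functional assay on HCT-116 cells (Homo sapiens) for cytotoxicity, read by MTT assay, with a stated time of 72 h; a lower number here means a stronger inhibitor, a higher number a weaker inhibitor; this is a limit of the assay rather than a number.
Compound 2 `CC(=O)O[C@@H]1C[C@@H](C)[C@](O)(CCC2=CC(=O)OC2)[C@@]2(C)CCCC(C)(C)[C@H]12` gives < 5 ug/mL in this assay, again a limit and not a number.
Compound 3 `CC1=C(CC[C@@H](C)C(=O)CCC2=CC(=O)OC2)C(C)(C)CCC1` gives < 5 ug/mL in this assay, likewise only a limit.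

Within the data shown here, compound 2 therefore cannot be placed within the set: the three measured compounds all sit at the limit of < 5 ug/mL in this assay, at which 3 of the 3 values shown sit, so none can be called stronger or weaker than another, and no step between any two of them can be sized. Among the measured compounds shown here, no measured pair differing in a single place exists in these data.

The unmeasured compound 4 `C[C@@H]1C[C@@H](O)[C@H]2C(C)(C)CCC[C@]2(C)[C@@]1(O)CCC1=CC(=O)OC1` is compound 2 with one change, (hydrogen in place of acetyl on an oxygen on a saturated carbon). The remainder of the shared core, including the alcohol and the unsaturated lactone side chain, is kept.

For the measured compounds named here, with every measured value a limit, there is no step in this assay from which to judge the effect of removing the acetyl. The expectation is a step from compound 2 to compound 4 of a step that the limit leaves unreadable from compound 2 to compound 4, that is, none clearly beyond the scatter, with a slight lean toward weaker. Compound 4 is expected to give about 4 ug/mL in this assay, within 1.5 ug/mL to 12 ug/mL, so that a further limit is quite possible.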

Compound 4, half-maximal inhibitory concentration: < 5 ug/mL
Compound 4 gave a limit, no number; the forecaster's own chance of this, stated with the estimate: 50%; the middle value is on the limit's open side.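

In this assay compound 4 gives < 5 ug/mL as a limit and not a number. Among these compounds, compound 2 also has only a limit, so no step between compound 2 and compound 4 can be read: the limit of < 5 ug/mL in this assay, at which 4 of the 4 values shown sit.

The compounds shown leave open how strong in this assay each one actually is, and whether replacing acetoxy with hydroxy changes that strength at all.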